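The source may hold more compounds than are shown below. What is called first, only, known or untested is meant among the compounds shown, and "the series" means these compounds.

Measured so far in a physicochemical assay for lipophilicity, at pH 7.4; a lower number here means a more polar compound, a higher number a more lipophilic compound:

- compound 1 `CS(=O)(=O)N1C[C@H](C(=O)Nc2ccc(Cl)cc2)[C@@H](C(=O)Nc2ccc(-n3ccccc3=O)cc2F)C1` gives 2.17 here
- compound 2 `COc1ccc(NC(=O)[C@H]2CN(S(C)(=O)=O)C[C@@H]2C(=O)Nc2ccc(-n3ccccc3=O)cc2F)cc1` gives 1.19 here

Of these two, compound 2 has the lower number at 1.19 in this assay and compound 1 lies beyond the scatter above it. Compound 3 `COc1ccc(NC(=O)[C@H]2CN(S(C)(=O)=O)C[C@@H]2C(=O)Nc2ccc(-n3ccccc3=O)cc2F)cc1F` differs from compound 2 in one place, with fluoro in place of hydrogen on an aromatic carbon, ortho to a methoxy group: fluoro in place of hydrogen on an aromatic carbon is the whole difference. For the measured compounds named here, only one measured step bears on this ring, and a number 0.98 log units lower from compound 1 to compound 2 (beyond the scatter) is modest. That step swaps one group for another, while here a fluoro replaces a hydrogen, so it offers a sense of scale and no direct guide. A small rise is expected, smaller than a number 0.98 log units lower from compound 1 to compound 2 (beyond the scatter) and possibly within the scatter. The expected step is a number 0.16 log units higher from compound 2 to compound 3 (within the scatter) on this estimate. The estimated value for compound 3 is 1.35 with an expected range of 1.05 to 1.7 before any measurement.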

Compound 3, distribution coefficient: 0.56
For compound 3 the middle estimate is 0.79 log units above the measured one, and the stated range ends above it.
By their numbers in this assay, from the lowest: compound 3; then compound 2; then compound 1.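

Adding one fluoro, a single heavy atom with no hydrogen-bond donors or acceptors counted and no net charge, ortho to the methoxy group gives a step beyond the scatter in this assay: a number 0.63 log units lower from compound 2 to compound 3 (beyond the scatter). Both changes shown on this ring lower the number, and the full replacement of 4-chlorophenyl by 3-fluoro-4-methoxyphenyl adds up to a number 1.61 log units lower from compound 1 to compound 3 (beyond the scatter), a large step. No measurement available here accounts for the direction of the fluoro step.

Going by these compounds, whether a fluoro at this place lowers the number only when the methoxy group is present remains open, as compound 3 is the only fluoro case on this ring. On these data alone, how a nitrile or an amine at the same place would read in this assay is also open.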